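A Chloro for Cyano Swap at the Assay Limit

A few compounds are considered here, and "the series" means these few. Any claim that something is new, unique, unknown or untested is made for them only; others in the source may bear on it.

In a functional assay on HUVEC cells (Homo sapiens) for antiproliferative activity, read by MTT assay, with a stated time of 24 h (a lower number here means a stronger inhibitor, a higher number a weaker inhibitor), compound 1 `COc1cc(OC)c(-c2coc3cc(OCc4ccccc4)ccc3c2=O)cc1OC` gives 9750 nM. Compound 2 `COc1cc(OC)c(-c2coc3cc(OCc4ccc(F)cc4)ccc3c2=O)cc1OC` returns only a limit, > 10000 nM. Compound 3 `COc1cc(OC)c(-c2coc3cc(OCc4ccc(C#N)cc4)ccc3c2=O)cc1OC` also returns only a limit, > 10000 nM. Compound 3 therefore has no exact number and shares (the limit of > 10000 nM in this assay, at which 2 of the 3 values shown sit).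

Compound 4 `COc1cc(OC)c(-c2coc3cc(OCc4ccc(Cl)cc4)ccc3c2=O)cc1OC` has chloro in place of cyano on an aromatic carbon, para to a large group: chloro in place of cyano on an aromatic carbon. Among the compounds with values here, no measured step makes this exact exchange, but three steps at the same place bear on it. Adding fluoro gives an at least 1.0-fold higher number from compound 1 to compound 2 (0.01 log units; that floor lies within the scatter), and adding cyano gives an at least 1.0-fold higher number from compound 1 to compound 3 (0.01 log units; that floor lies within the scatter). Exchanging fluoro for cyano gives a step that the two limits leave unreadable from compound 2 to compound 3. Neither of the first two steps shows a change beyond the scatter, and the third cannot be sized, so no clear direction can be drawn from them. In this assay, the expected step is small, with no change beyond the scatter: a step that the limit leaves unreadable from compound 3 to compound 4. Compound 4 is estimated at 12000 nM, with an expected range from 6000 nM to 30000 nM.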

Compound 4, half-maximal inhibitory concentration: 4400 nM
Compound 4: middle estimate off by 2.7-fold (0.44 log units), on the high side, outside the stated range (below it).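

Among the compounds shown, chloro is the only group at this place, para to a large group, that moves the number lower beyond the scatter: in this assay the change is a 2.2-fold lower number from compound 1 to compound 4 (0.35 log units; beyond the scatter). Against the two groups that end at the limit, the exchange gives an at least 2.2-fold lower number from compound 3 to compound 4 (0.35 log units; beyond the scatter) and an at least 2.2-fold lower number from compound 2 to compound 4 (0.35 log units; beyond the scatter), so this position does respond to the group it carries, and to more than the mere presence of a substituent. Those two steps are floors and not sizes: the limit of > 10000 nM in this assay, at which 2 of the 4 values shown sit.

From the compounds shown here alone, how far compound 2 and compound 3 truly lie from compound 4 stays open, and the step between compound 2 and compound 3 cannot be read. Going by these compounds, whether bromo or methyl at this carbon would go with chloro or with fluoro and cyano also remains open.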